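This account rests on a few compounds, and the source may have more. Where it says the series, first, only, none or still open, it means among the compounds named here.

Measured so far in a functional assay on aorta (Rattus norvegicus) for inhibition; a lower number here means a stronger inhibitor, a higher number a weaker inhibitor:
- compound 1 `CC(C)c1cccc(C2CNCC2C(=O)Nc2cc3cc[nH]c(=O)c3cc2Cl)c1` gives "not determined" (no result reported)
- compound 2 `CN1CCC(C(=O)Nc2cc3cc[nH]c(=O)c3cc2Cl)CC1` gives 250 nM

Compound 1 has no number, so it offers no measured starting point. Compound 3 `O=C(Nc1cc2cc[nH]c(=O)c2cc1Cl)C1CNCC1c1cccc(Br)c1` keeps the rest of compound 1 and changes one group, bromo in place of isopropyl on an aromatic carbon with bromo in place of isopropyl on an aromatic carbon. Among the measured compounds shown here, no measured pair shows what this swap does, so no step beyond the scatter is expected, in either direction. For the measured compounds named here, the only available number is compound 2 at 250 nM and its structure differs more widely, so the estimate stays loose. Compound 3 is expected near 150 nM with 30 nM to 700 nM as its estimated range.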

Compound 3, half-maximal inhibitory concentration: 63 nM
Compound 3: middle estimate off by 2.4-fold (0.38 log units), on the high side; low and high end bracket the measured number.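

Compound 1 and compound 3 yield no readable step in this assay. Going by these compounds, what bromo in place of isopropyl does to inhibition stays open. No supporting data bear on the value of compound 3.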